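The source may hold more compounds than are shown below. What is called first, only, known or untested is meant among the compounds shown, and "the series" means these compounds.

In an ADME assay on BJ cells (Homo sapiens) for cytotoxicity, read by CellTiter-Glo and resazurin assay, with a stated time of 72 h (on this read-out higher numbers stand for an effect only at larger amounts of compound and lower numbers for an effect already at smaller amounts), compound 2, `CCOC(=O)CCCCCOc1cccc(CN(C(=O)c2ccc(-c3cccc(F)c3)cc2)C(C)C)c1`, gives only a limit of the assay, > 26000 nM. Compound 1, `CCOC(=O)CCCCCOc1cccc(CN(C(=O)c2ccc(-c3cccc(OC)c3)cc2)C(C)C)c1`, carries a methoxy at the position where compound 2 carries the fluoro. In this assay compound 1 likewise gives only a limit, > 21000 nM. Going by the values given here, the one measured step, a step that the two limits leave unreadable from compound 1 to compound 2, therefore has no readable size, since both values sit at the limits the limit of > 21000 nM in this assay, at which 1 of the 2 values shown sits, and (the limit of > 26000 nM in this assay, at which 1 of the 2 values shown sits). Compound 3, `CCOC(=O)CCCCCOc1cccc(CN(C(=O)c2ccc(-c3cccc(C(F)(F)F)c3)cc2)C(C)C)c1`, carries the change (trifluoromethyl in place of fluoro on an aromatic carbon). Among the compounds with values here, no measured step gives a size for this kind of change, so the expectation for this assay rests only on the fact that both compounds known so far show no effect up to their limits. This change is expected to amount to a step that the limit leaves unreadable from compound 2 to compound 3, with a fair chance that compound 3 again yields only a limit. Compound 3 is estimated at 30000 nM, within a range from 10000 nM to 100000 nM.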

Compound 3, half-maximal effective concentration: < 1.3 nM
Compound 3 ended at the assay's limit; the forecaster's own chance of this, stated with the estimate: 70%; middle value at least 23000-fold (4.36 log units) away from the limit.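

At this place on the ring, the group matters far more than the first two compounds could show: in this assay, trifluoromethyl in place of fluoro gives an at least 20000-fold lower number from compound 2 to compound 3 (4.30 log units; beyond the scatter), and trifluoromethyl in place of methoxy gives an at least 16000-fold lower number from compound 1 to compound 3 (4.20 log units; beyond the scatter). Fluoro and methoxy cannot be ordered against each other, but changing this one group separates two compounds with no effect up to their limits from one that acts at very small amounts. The true size of both steps may be larger still, as the value of compound 3 is itself a limit and not a number: the limit of < 1.3 nM in this assay, at which 1 of the 3 values shown sits.

The compounds shown do not explain why trifluoromethyl differs so sharply from fluoro and methoxy. As far as these compounds go, it also remains open whether chloro or nitrile at this place would act like trifluoromethyl, and whether the effect would survive a carboxylic acid in place of the ethyl ester.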